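From hydroxyphenyl to phenylethenyl: a cytotoxicity expectation

This account rests on a few compounds, and the source may have more. Where it says the series, first, only, none or still open, it means among the compounds named here.

Compound 1 (`O=C(c1ccncc1)N1N=C(c2cc3ccccc3o2)CC1c1ccc(Cl)cc1`) and compound 2 (`CCn1cc(C(=O)N2N=C(c3cc4ccccc4o3)CC2c2ccc(O)cc2)c(=O)c2ccc(C)nc21`) share a core and were both tested in an ADME assay on Vero cells (Chlorocebus sabaeus) for cytotoxicity, read by MTT assay, with a stated time of 72 h; on this read-out lower numbers stand for stronger inhibition and higher numbers for weaker inhibition. Compound 1 in this assay gives only a limit, > 220000 nM. Compound 2 in this assay likewise gives only a limit, > 148000 nM. Compound 2 therefore stands at the edge of what this assay reports, as does compound 1 (the limit of > 148000 nM in this assay, at which 1 of the 2 values shown sits, (the limit of > 220000 nM in this assay, at which 1 of the 2 values shown sits)), and the two values show nothing beyond their limits.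

Compound 3 (`CCn1cc(C(=O)N2N=C(c3cc4ccccc4o3)CC2/C=C/c2ccccc2)c(=O)c2ccc(C)nc21`) differs from compound 2 in one place: 2-phenylethenyl in place of 4-hydroxyphenyl on a saturated ring carbon, on a saturated ring carbon of a five-membered non-aromatic ring with 2 nitrogen, next to the ring nitrogen. Going by the values given here, no measured pair shows this change, so no step size is known, and with both measured compounds at limits no trend in this assay can be read. Compound 3 is expected to give about 200000 nM in this assay, between 80000 nM and 500000 nM. The expected change from compound 2 to compound 3 is a step that the limit leaves unreadable from compound 2 to compound 3, nothing beyond the scatter, most likely another limit.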

Compound 3, half-maximal inhibitory concentration: > 168000 nM
Compound 3: only a limit was reported; the forecaster's own chance of this, stated with the estimate: 75%; the middle value lies beyond the limit too.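

In this assay compound 2 and compound 3 both give only limits, so no step can be read for 2-phenylethenyl in place of 4-hydroxyphenyl on a saturated ring carbon. The compounds shown leave open what numerical value any of them would have in this assay, and how far this change would move it.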